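The source may hold more compounds than are shown below. What is called first, only, known or untested is meant among the compounds shown, and "the series" means these compounds.

The three measured compounds share one core and differ only in the group on an aromatic carbon. In an ADME assay on HFF cells (Homo sapiens) for cytotoxicity, with a stated time of 8 days (on this read-out higher numbers stand for lower toxicity in this test and lower numbers for higher toxicity in this test), compound 1 `CCCCCCSc1nc(N)nc2c1ncn2/C=C1/CC1(CO)CO` reaches only a limit, > 300000 nM. Compound 2 `CSc1nc(N)nc2c1ncn2/C=C1/CC1(CO)CO` likewise gives only a limit, > 300000 nM. Compound 3 `CCOc1nc(N)nc2c1ncn2/C=C1/CC1(CO)CO` also stands at a limit, > 300000 nM. The steps a step that the two limits leave unreadable from compound 1 to compound 2, a step that the two limits leave unreadable from compound 1 to compound 3 and a step that the two limits leave unreadable from compound 2 to compound 3 therefore have no readable size, since (the limit of > 300000 nM in this assay, at which 3 of the 3 values shown sit). Compound 4 `CC(C)Sc1nc(N)nc2c1ncn2/C=C1/CC1(CO)CO` differs from compound 3 by isopropylsulfanyl in place of ethoxy on an aromatic carbon. Within the data shown here, no measured step bears on this change with a readable size, so no step beyond the scatter is expected in this assay. Compound 4 is therefore expected to sit again at the limit, estimated as 400000 nM with a range from 200000 nM to 1000000 nM, which means an expected step that the limit leaves unreadable from compound 3 to compound 4.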

Compound 4, half-maximal cytotoxic concentration: > 300000 nM
Compound 4 gave a limit, no number; the forecaster's own chance of this, stated with the estimate: 85%; the middle value does not contradict the limit.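

Compound 4 adds no readable step to compound 1, compound 2 or compound 3 in this assay, because all of them stand at a limit: the limit of > 300000 nM in this assay, at which 4 of the 4 values shown sit.

The compounds shown leave open whether the groups on the aromatic carbon differ at all in this read-out.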